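Aryl-to-pyrazinyl swap on the oxazolone carbamate series

This account rests on a few compounds, and the source may have more. Where it says the series, first, only, none or still open, it means among the compounds named here.

Compound 1 `O=C(NCCCCc1ccccc1)n1cc(-c2ccccc2)oc1=O` is the parent of this small set. In an assay on isolated protein for inhibition of acid ceramidase (Homo sapiens), read by LC-MS, with a stated time of 1 h (on this read-out lower numbers stand for stronger inhibition and higher numbers for weaker inhibition), compound 1 gives 90 nM, the second highest of the three numbers recorded. Its nearest neighbour is compound 2 `O=C(NCCCCc1ccccc1)n1cc(-c2ccc(Cl)cc2)oc1=O`, which in this assay gives 83 nM; the step of a 1.1-fold lower number from compound 1 to compound 2 (0.04 log units; within the scatter) is chloro in place of hydrogen on an aromatic carbon. Furthest from it is compound 3 `COc1ccccc1-c1cn(C(=O)NCCCCc2ccccc2)c(=O)o1`, which in this assay gives 177 nM; the step of a 2.0-fold higher number from compound 1 to compound 3 (0.29 log units; within the scatter) is methoxy in place of hydrogen on an aromatic carbon. Between those two, the step of a 2.1-fold higher number from compound 2 to compound 3 (0.33 log units; beyond the scatter) is 2-methoxyphenyl in place of 4-chlorophenyl on an aromatic carbon.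

Compound 4 `O=C(NCCCCc1ccccc1)n1cc(-c2cnccn2)oc1=O` is not yet measured. From compound 1 the change is pyrazin-2-yl in place of phenyl on an aromatic carbon. Among the compounds with values here, none of the measured steps replaces ring carbons of the aryl group by nitrogen; the closest bearing steps only decorate that phenyl, and both stay small. The phenyl ring therefore tolerates modification without a large shift, and the expected step of a 1.8-fold higher number from compound 1 to compound 4 (0.25 log units; within the scatter) in this assay is modest, most likely toward a slightly higher number. For compound 4 the estimated value in this assay is 160 nM, with an expected range from 60 nM to 450 nM.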

Compound 4, half-maximal inhibitory concentration in the acid ceramidase assay: 32 nM
Compound 4: middle estimate off by 5.0-fold (0.70 log units), on the high side; measured number outside the range, below it.
By their numbers in the acid ceramidase assay, from the lowest: compound 4; then compounds 2, 1 and 3 (each within the scatter of the next, the first and the last beyond it).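

In the acid ceramidase assay, the decorations of the phenyl ring stay within the scatter from the parent, whereas exchanging that ring as a whole for pyrazin-2-yl, an aromatic ring with 2 hetero atoms, gives a 2.8-fold lower number from compound 1 to compound 4 (0.45 log units; beyond the scatter). The same exchange measured against the substituted aryl groups gives a 2.6-fold lower number from compound 2 to compound 4 (0.41 log units; beyond the scatter) and a 5.5-fold lower number from compound 3 to compound 4 (0.74 log units; beyond the scatter), so compound 4 is the most potent of the four, with its steps to all the others beyond the scatter. The position next to the ring oxygen therefore accepts nitrogen within the aryl ring, and in this set that change moves the read-out further from the parent than either substituent on phenyl does.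

In a physicochemical assay for solubility, read by HPLC, in phosphate buffer, measured as kinetic solubility, with a stated time of 1 h, at pH 7.4, tested at 250 uM (on this read-out lower numbers stand for lower solubility and higher numbers for higher solubility), compound 4 gives < 1000 nM, a limit of the assay. In the physicochemical assay compound 1 gives < 1000 nM, also a limit of the assay, so the step between them cannot be read: the limit of < 1000 nM in the physicochemical assay, at which 2 of the 2 values shown sit. The compounds shown do not tell whether both ring nitrogens of pyrazin-2-yl are needed, a question that a pyridin-2-yl or pyrimidin-4-yl ring at this position, or an amino or methyl group on the pyrazin-2-yl ring, would address.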